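Lengthening the ether chain on an N-cyclohexyl analogue

The compounds below may be only part of what the source reports. "The series", "measured", "known", "first", "only" and "open" are said of these compounds alone.

Measured compounds:
- compound 1, `CCCCCCCCCCOc1ccc(-c2c(C)[nH]c(=O)n2C)cc1`: 0.1 mg/kg
- compound 2, `CCCCCCCCOc1ccc(-c2c(C)[nH]c(=O)n2C2CCCCC2)cc1`: 30 mg/kg

In a functional assay on the whole organism with Rattus norvegicus as the target (a higher number here means that more compound is needed for the effect, a lower number that less compound is needed), compound 1 gives 0.1 mg/kg, while compound 2 gives 30 mg/kg, the highest of the two numbers and beyond the scatter from compound 1. Compounds 1 and 2 differ in more than one place, so the contribution of the ether chain alone cannot be read from them. Compound 3, `CCCCCCCCCCOc1ccc(-c2c(C)[nH]c(=O)n2C2CCCCC2)cc1`, has not yet been measured in this assay. It differs from compound 2 by ethyl in place of hydrogen on a saturated chain carbon, eight bonds along the chain from an oxygen on an aromatic ring. For the measured compounds named here, with no single-change step available, the expectation rests on the direction suggested by compound 1 and its value of 0.1 mg/kg. Compound 3 is expected to give 15 mg/kg, within 3 mg/kg to 60 mg/kg, a modest step from compound 2 to compound 3 of a 2.0-fold lower number from compound 2 to compound 3 (0.30 log units; within the scatter) toward a lower number, not far beyond the scatter.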

Compound 3, minimum effective dose: 0.1 mg/kg
For compound 3 the middle estimate is 150-fold (2.18 log units) above the measured one; measured number below the stated range.
By their numbers in this assay, from the lowest: compounds 1 and 3 (each within the scatter of the next); then compound 2.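

In this assay, ethyl in place of hydrogen on a saturated chain carbon, eight bonds along the chain from an oxygen on an aromatic ring, gives a 300-fold lower number from compound 2 to compound 3 (2.48 log units; beyond the scatter), so this place on the chain carries great weight when cyclohexyl sits on the aromatic nitrogen. The other new pair isolates that nitrogen group: cyclohexyl in place of methyl on an aromatic nitrogen shows no change at the digits printed from compound 1 to compound 3 (within the scatter), so with this chain the two groups cannot be told apart. Nothing available explains either result.

On these data alone, it remains open whether a longer chain than that of compound 3 would hold the same number, and whether the chain step would be as large with methyl on the aromatic nitrogen. As far as these compounds go, how an amine in place of the ethyl would read in this assay also remains open.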